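The source may hold more compounds than are shown below. What is called first, only, known or untested is meant among the compounds shown, and "the series" means these compounds.

Among the measured compounds shown here, in a functional assay on KYSE-450 cells (Homo sapiens) for inhibition, read by MTT assay, with a stated time of 48 h (on this read-out lower numbers stand for stronger inhibition and higher numbers for weaker inhibition), compound 2 (`C/C=C/C(=O)N(Cc1ccc(OC)c(O)c1)c1cc(OC)c(OC)c(OC)c1`) gives 67 nM, the lower of the two numbers measured so far. Compound 1 (`COc1ccc(CN(C(=O)CCl)c2cc(OC)c(OC)c(OC)c2)cc1O`) gives 210 nM. Compound 3 (`COc1ccc(CN(C(=O)/C=C/CBr)c2cc(OC)c(OC)c(OC)c2)cc1O`) has not yet been measured and departs from compound 2 in one place: bromo in place of hydrogen on a saturated chain carbon bound to a double-bonded chain carbon. This turns the prop-1-en-1-yl into 3-bromoprop-1-en-1-yl, with bromo in place of hydrogen on a saturated chain carbon bound to a double-bonded chain carbon.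

For the measured compounds named here, only one measured step bears on this change: a 3.1-fold lower number from compound 1 to compound 2 (0.50 log units; beyond the scatter). In that step, prop-1-en-1-yl took the place of chloromethyl on a carbonyl carbon, and the change was modest but beyond the scatter. Going by the values given here, it touches the same carbonyl substituent, but no measured pair adds a bromo to the chain, so the evidence is indirect. Compound 1 does show that a halogen-bearing chain at this carbonyl still gives 210 nM. A small shift towards a lower number is therefore expected in this assay, with the estimate being a 1.7-fold lower number from compound 2 to compound 3 (0.22 log units; within the scatter). The expected value for compound 3 is 40 nM, within an estimated range of 10 nM to 150 nM.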

Compound 3, half-maximal inhibitory concentration: 100 nM
Compound 3: middle estimate off by 2.5-fold (0.40 log units), on the low side, and the stated range covers the measured number.
By their numbers in this assay, from the lowest: compounds 2 and 3 (each within the scatter of the next); then compound 1.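

In this assay, bromo in place of hydrogen on a saturated chain carbon bound to a double-bonded chain carbon gives a 1.5-fold higher number from compound 2 to compound 3 (0.17 log units; within the scatter), so within this read-out the methyl and bromomethyl ends of the chain cannot be told apart. The 3-bromoprop-1-en-1-yl group also stands apart from chloromethyl on the carbonyl carbon, with a 2.1-fold lower number from compound 1 to compound 3 (0.32 log units; beyond the scatter), so among these three compounds both prop-1-en-1-yl chains, with or without bromo, give numbers beyond the scatter of compound 1. Nothing among the available data explains this outcome.

The compounds shown leave open whether the end of the chain tolerates other groups in the same way, such as a hydroxyl, a dimethylamino group or a longer chain, and whether any of these would move the number beyond the scatter of compound 2. They also leave open whether the double bond matters for this result, since a saturated propyl chain on the carbonyl carbon, with or without bromo, does not appear among them.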